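Nitro substitution on two anilide cores in HEK293 cytotoxicity

The compounds below may be only part of what the source reports. "The series", "measured", "known", "first", "only" and "open" are said of these compounds alone.

This study compares four anilides, of which three have been measured in an ADME assay on HEK293 cells (Homo sapiens) for cytotoxicity, read by MTT assay, with a stated time of 48 h; on this read-out higher numbers stand for weaker inhibition and lower numbers for stronger inhibition. Compound 1, `Cc1cc(NC(=O)c2ccc(Cl)cc2)ccc1NS(C)(=O)=O`, gives 50300 nM. Compound 2, `Cc1cc(NC(=O)c2ccc(Cl)c([N+](=O)[O-])c2)ccc1NS(C)(=O)=O`, carries the change nitro in place of hydrogen on an aromatic carbon and gives 73100 nM. The step between the two is a 1.5-fold higher number from compound 1 to compound 2 (0.16 log units; within the scatter). Compound 3, `CCS(=O)(=O)Nc1ccc(NC(=O)c2ccc(Cl)cc2)cc1Cl`, has a different core, and the difference between the two cores is not broken down here. For compound 3 this assay reports only a limit, > 250000 nM, and not a number. Compound 3 thus sits at the limit of > 250000 nM in this assay, at which 1 of the 3 values shown sits.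

Compound 4, `CCS(=O)(=O)Nc1ccc(NC(=O)c2ccc(Cl)c([N+](=O)[O-])c2)cc1Cl`, is not yet measured. It carries the same change as compound 2 on the core of compound 3: nitro in place of hydrogen on an aromatic carbon. For the measured compounds named here, since the single measured example of this change stayed within the scatter, and since compound 3 already sits at the limit, the value of compound 4 is expected to remain at or near that limit, with a fair chance that this assay again reports only a limit. The expected step is a number no higher from compound 3 to compound 4 (the limit leaves the size open), and this expectation rests on the measured step of a 1.5-fold higher number from compound 1 to compound 2 (0.16 log units; within the scatter) together with the limit of compound 3. Compound 4 is estimated to give 250000 nM in this assay, with a range from 120000 nM to 600000 nM.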

Compound 4, half-maximal inhibitory concentration: 63800 nM
Compound 4: middle estimate off by 3.9-fold (0.59 log units), on the high side; measured number outside the range, below it.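

In this assay, nitro in place of hydrogen on an aromatic carbon gives an at least 3.9-fold lower number from compound 3 to compound 4 (0.59 log units; beyond the scatter), so the change did not behave alike on the two cores: the same change on two cores in this assay, a 1.5-fold higher number (0.16 log units; within the scatter) from compound 1 to compound 2 and an at least 3.9-fold lower number (0.59 log units; beyond the scatter) from compound 3 to compound 4, at least 5.6-fold (0.75 log units) apart, beyond the scatter of two such steps

The result on the core of compound 1 therefore did not carry over to the core of compound 3, and the second step has only a lower bound, since its starting point is a limit: the limit of > 250000 nM in this assay, at which 1 of the 4 values shown sits.

This shows that, in these two matched pairs, the effect of the nitro group depends on the core it is placed on, but it does not show which feature of the cores is responsible or why, and with one pair per core it sets up no rule for the series.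

The compounds shown leave open which part of the difference between the two cores goes with the split, as no pair separates those parts one at a time. They also leave open whether an amine or a nitrile in place of the nitro group would split between the two cores in the same way.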